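The source may hold more compounds than are shown below. What is called first, only, known or untested is meant among the compounds shown, and "the series" means these compounds.

Measured compounds:
compound 1 `Cc1nc(S(C)(=O)=O)ccc1Oc1ncnc(OC2CCN(C(=O)OC(C)(C)C(F)(F)F)CC2)c1F` — 6.53 nM
compound 2 `Cc1nc(S(C)(=O)=O)ccc1Oc1ncnc(OC2CCN(C(=O)OC(C)(C)CF)CC2)c1F` — 19.9 nM
compound 3 `Cc1nc(S(C)(=O)=O)ccc1Oc1ncnc(OC2CCN(C(=O)O[C@@H](C)CF)CC2)c1F` — 186 nM

In a functional assay on isolated protein for inhibition of Glucose-dependent insulinotropic receptor (Homo sapiens), read by HTRF and cAMP accumulation (on this read-out higher numbers stand for an effect only at larger amounts of compound and lower numbers for an effect already at smaller amounts), compound 3 gives the highest number of the three, so it acts only at the largest amounts; compound 2 stands nearest and compound 1 furthest. Both steps towards it go in the same direction: a 28-fold higher number from compound 1 to compound 3 (1.45 log units; beyond the scatter) and a 9.3-fold higher number from compound 2 to compound 3 (0.97 log units; beyond the scatter).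

Compound 4 `Cc1nc(S(C)(=O)=O)ccc1Oc1ncnc(OC2CCN(C(=O)SC3(C)CC3)CC2)c1F` is the next compound and has not yet been measured. It differs from compound 3 in this way: a group of 5 heavy atoms (4 carbon, 1 sulfur; one three-membered non-aromatic ring of carbon only) in place of a group of 5 heavy atoms (3 carbon, 1 oxygen, 1 fluorine; no ring), on a carbonyl carbon.

Among the measured compounds shown here, no measured step swaps oxygen for sulfur on the carbonyl carbon, so this part of the change has no precedent here. What the measured steps do show is that a fuller branching at the carbon bound to that oxygen lowers the number: a 9.3-fold higher number from compound 2 to compound 3 (0.97 log units; beyond the scatter) in the reverse direction, and a 3.0-fold higher number from compound 1 to compound 2 (0.48 log units; beyond the scatter) within the branched series. Compound 4 carries a branched group again, a ring on its sulfur, so a step back towards compound 2 is expected, but the sulfur makes the size uncertain. The expected step is a 6.2-fold lower number from compound 3 to compound 4 (0.79 log units; beyond the scatter); compound 4 is estimated at 30 nM, in the range 8 nM to 120 nM.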

Compound 4, half-maximal effective concentration: 13.2 nM
The estimate for compound 4 lay 2.3-fold (0.36 log units) above the measured number, within the range that was stated.
By their numbers in this assay, from the lowest: compound 1; then compounds 4 and 2 (each within the scatter of the next); then compound 3.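

In this assay, the step to a sulfur-linked group with a three-membered carbon ring is a 14-fold lower number from compound 3 to compound 4 (1.15 log units; beyond the scatter), which shows that the carbonyl carbon can carry a group with sulfur in place of oxygen and with no fluorine at all while the number still falls. Compared with the fluorine-bearing group of compound 2, the step is a 1.5-fold lower number from compound 2 to compound 4 (0.18 log units; within the scatter), so these two groups cannot be told apart here, whereas a 2.0-fold higher number from compound 1 to compound 4 (0.31 log units; beyond the scatter) leaves compound 1 at the lowest number of the four. No measurement is available here to explain why these groups rank as they do.

Sulfur and the ring enter together in compound 4, so the compounds shown cannot say how much of the step belongs to each. Open questions are what the same three-membered ring would give when linked through oxygen, and what an amine nitrogen in place of the sulfur or a four-membered cyclobutyl ring in place of the three-membered ring would give.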